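Swapping thiophen-3-yl for thiophen-2-yl on compound 2

The compounds below may be only part of what the source reports. "The series", "measured", "known", "first", "only" and "open" are said of these compounds alone.

In a functional assay on cells (Cancer cell lines, Homo sapiens) for inhibition (a higher number here means a weaker inhibitor of growth, a lower number a stronger inhibitor of growth), compound 2 `Cc1cn2c(/C=N/NC(=N)N)c(-c3ccsc3)nc2s1` gives 7590 nM and sits level, within the scatter, with compound 1 `Cc1cn2c(/C=N/Nc3ccccn3)c(-c3ccc(Cl)c([N+](=O)[O-])c3)nc2s1` at 11700 nM and compound 3 `N=C(N)N/N=C/c1c(-c2ccsc2)nc2sccn12` at 14800 nM on the same scale. Compound 4 `Cc1cn2c(/C=N/NC(=N)N)c(-c3cccs3)nc2s1` carries thiophen-2-yl in place of thiophen-3-yl on an aromatic carbon. The change is thiophen-2-yl in place of thiophen-3-yl on an aromatic carbon and the two compounds hold the same atoms, joined differently. Within the data shown here, the one measured step, hydrogen in place of methyl, is a 1.9-fold higher number from compound 2 to compound 3 (0.29 log units; within the scatter) and leaves the thiophene untouched, so it offers only a loose guide. No shift beyond the scatter is expected, and the expected step is a 1.1-fold higher number from compound 2 to compound 4 (0.05 log units; within the scatter) in size. For compound 4 the estimated value is 8500 nM (range 3500 nM to 20000 nM).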

Compound 4, concentration for 50% growth inhibition: 3020 nM
Beside the measured number, compound 4's estimate is 2.8-fold (0.45 log units) above it; the measured number lies below the stated range.
By their numbers in this assay, from the lowest: compound 4; then compounds 2, 1 and 3 (each within the scatter of the next).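

In this assay, moving the thiophene's point of attachment from thiophen-3-yl to thiophen-2-yl gives a 2.5-fold lower number from compound 2 to compound 4 (0.40 log units; beyond the scatter), a modest gain in growth inhibition that lies beyond the scatter. The compounds hold the same atoms, so at this place on the shared core, how the ring is joined matters, which the earlier within-scatter step could not show. Nothing measured here explains the difference. As far as these compounds go, whether compound 3, which lacks the methyl, would respond in the same way remains open. So does how furan-2-yl or unsubstituted phenyl would compare at this place.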